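Hydroxy chain change from compound 2 to compound 3

The compounds below may be only part of what the source reports. "The series", "measured", "known", "first", "only" and "open" are said of these compounds alone.

Values in a functional assay on the whole organism (stomach) with Rattus norvegicus as the target; on this read-out lower numbers stand for an effect already at smaller amounts and higher numbers for an effect only at larger amounts of compound:
compound 1 `CCCCCCCC/N=C/N1CCC(C(c2ccccc2)c2ccccc2)CC1`: 0.6 mg/kg
compound 2 `OCCCCCCCC/N=C/N1CCC(C(c2ccccc2)c2ccccc2)CC1`: 0.44 mg/kg
not yet measured: compound 3 `OCCCCCC/N=C/N1CCC(C(c2ccccc2)c2ccccc2)CC1`

Going by the values given here, compound 2 stands within the scatter of compound 1, its only neighbour on these numbers, so the two do not separate. The change leading to compound 3 is hydroxy in place of 2-hydroxyethyl on a saturated chain carbon, six bonds along the chain from a double-bonded nitrogen. Among the compounds with values here, the one measured step that bears on it is a 1.4-fold lower number from compound 1 to compound 2 (0.13 log units; within the scatter). That step is a different change: hydroxy in place of hydrogen on a saturated chain carbon, eight bonds along the chain from a double-bonded nitrogen. Within the data shown here, no measured step covers hydroxy in place of 2-hydroxyethyl, so the guidance is weak. Among the measured compounds shown here, with only that small step to go on, no step beyond the scatter is expected in this assay, and no direction can be given. The expected change is a 1.1-fold higher number from compound 2 to compound 3 (0.06 log units; within the scatter). For compound 3 the estimated value is 0.5 mg/kg, with an expected range of 0.2 mg/kg to 1.3 mg/kg.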

Compound 3, dose for half-maximal effect: 2 mg/kg
Beside the measured number, compound 3's estimate is 4.0-fold (0.60 log units) below it; measured number outside the range, above it.
By their numbers in this assay, from the lowest: compounds 2 and 1 (each within the scatter of the next); then compound 3.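

In this assay, going by these compounds alone, hydroxy in place of 2-hydroxyethyl on a saturated chain carbon, six bonds along the chain from a double-bonded nitrogen, gives a 4.5-fold higher number from compound 2 to compound 3 (0.66 log units; beyond the scatter), the first step in these compounds to pass the scatter. Hydroxy in place of ethyl at the same place gives a 3.3-fold higher number from compound 1 to compound 3 (0.52 log units; beyond the scatter), so among these three compounds the shortened hydroxy chain separates from both longer chains, whereas adding hydroxy to the longer chain did not produce a separation. No measurement bears on why the number rises at this position.

From the compounds shown here alone, it remains open whether a plain hexyl chain would follow compound 3 or stay with compound 1, which would separate chain length from the hydroxy. Also open, going by these compounds, is how an amine or a carboxylic acid at the chain end would read.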